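Terminal Carboxy Replaced by a Hydroxy-Bearing Chain

The source may report more compounds than this note shows. Statements on the series, on what has been measured and on what is new or still open speak of the compounds shown alone.

Compound 1 `CC#CCC(C)[C@H](O)/C=C/[C@H]1[C@H](O)C[C@]2(C#CCCCO)C/C(=C\CCCC(=O)O)C[C@H]12` gives 10 nM in a functional assay for inhibition, with Homo sapiens as the target; on this read-out higher numbers stand for weaker inhibition and lower numbers for stronger inhibition. Compound 2 `CC#CCC(C)[C@H](O)/C=C/[C@H]1[C@H](O)C[C@]2(C#CCCCI)C/C(=C\CCCC(=O)O)C[C@H]12` gives 5 nM. Compound 3 `CC#CCC(C)[C@H](O)/C=C/[C@H]1[C@H](O)C[C@]2(C#CCCC(=O)O)C/C(=C\CCCC(=O)O)C[C@H]12` gives 2000 nM.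

Compound 3 stands highest of the three numbers: a 200-fold higher number from compound 1 to compound 3 (2.30 log units; beyond the scatter) and a 400-fold higher number from compound 2 to compound 3 (2.60 log units; beyond the scatter), both large and beyond the scatter, while a 2.0-fold lower number from compound 1 to compound 2 (0.30 log units; within the scatter) lies within it. Compound 4 `CC#CCC(C)[C@H](O)/C=C/[C@H]1[C@H](O)C[C@]2(CCC#CCCCO)C/C(=C\CCCC(=O)O)C[C@H]12` differs from compound 3 by 7-hydroxyhept-3-yn-1-yl in place of 4-carboxybut-1-yn-1-yl on a saturated ring carbon. This change removes the carboxy whose introduction gave the two large steps and restores a hydroxy terminus as in compound 1, though on a longer chain. For compound 4 the step expected in this assay is a 100-fold lower number from compound 3 to compound 4 (2.00 log units; beyond the scatter), a large drop. Compound 4 is therefore estimated at 20 nM, with a range from 5 nM to 100 nM.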

Compound 4, half-maximal inhibitory concentration: 400 nM
Estimate against measurement, compound 4: 20-fold (1.30 log units) below; measured number outside the range, above it.
By their numbers in this assay, from the lowest: compounds 2 and 1 (each within the scatter of the next); then compound 4; then compound 3.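

In this assay, replacing the carboxy-ending chain recovers only part of the loss, with a 5.0-fold lower number from compound 3 to compound 4 (0.70 log units; beyond the scatter) as the step. A hydroxy terminus alone therefore does not restore the lower numbers at this saturated ring carbon: 7-hydroxyhept-3-yn-1-yl still gives a 40-fold higher number from compound 1 to compound 4 (1.60 log units; beyond the scatter) and an 80-fold higher number from compound 2 to compound 4 (1.90 log units; beyond the scatter) as its steps. Nothing measured here explains these differences.

Chain length and the placing of the triple bond change together in compound 4, so their separate contributions remain open. So does the outcome with an amine at the end of the longer chain.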